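Shrinking the bicyclic aryl back toward phenyl

The compounds below may be only part of what the source reports. "The series", "measured", "known", "first", "only" and "open" are said of these compounds alone.

The measured compounds:
Compound 1, `O=C(O)c1ccc(CCCN2C(=O)CC[C@@H]2CCC(O)Cc2ccccc2)s1`, 1.7 nM
Compound 2, `O=C(O)c1ccc(CCCN2C(=O)CC[C@@H]2CCC(O)Cc2ccc3ccccc3c2)s1`, 500 nM

In a functional assay on HEK293 cells with prostaglandin E2 receptor EP4 subtype (Rattus norvegicus) as the target, read by cAMP accumulation (a higher number here means that more compound is needed for the effect, a lower number that less compound is needed), compound 2 gives 500 nM, the highest of the two numbers; its nearest neighbour is compound 1 with 1.7 nM. The step from compound 2 leads to compound 3, `O=C(O)c1ccc(CCCN2C(=O)CC[C@@H]2CCC(O)Cc2ccc(Cl)cc2)s1`, which carries 4-chlorophenyl in place of naphthalen-2-yl on a saturated chain carbon, two bonds along the chain from an oxygen on a saturated carbon. For the measured compounds named here, only one measured step bears on this: the change of phenyl into naphthalen-2-yl gave a 290-fold higher number from compound 1 to compound 2 (2.47 log units; beyond the scatter). Compound 3 keeps a single six-membered aromatic ring, so its 4-chlorophenyl group is nearer to compound 1 than to compound 2, and a large drop in this assay, back toward the value of compound 1, is expected, though the chlorine leaves some uncertainty. The expected step is a 100-fold lower number from compound 2 to compound 3 (2.00 log units; beyond the scatter). For compound 3 the estimate in this assay is 5 nM, with a range from 1.5 nM to 30 nM.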

Compound 3, half-maximal effective concentration: 40 nM
Estimate against measurement, compound 3: 8.0-fold (0.90 log units) below; measured number outside the range, above it.
By their numbers in this assay, from the lowest: compound 1; then compound 3; then compound 2.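

In this assay, 4-chlorophenyl recovers part of what naphthalen-2-yl lost, with a 13-fold lower number from compound 2 to compound 3 (1.10 log units; beyond the scatter). Yet chloro in place of hydrogen on an aromatic carbon has a large effect of its own, with a 24-fold higher number from compound 1 to compound 3 (1.37 log units; beyond the scatter). On this saturated chain carbon, then, a single six-membered aromatic ring does not by itself restore the number of compound 1, and compound 3 ranks between compound 1 and compound 2, with both steps beyond the scatter. Nothing available gives a cause for either step. From the compounds shown here alone, it remains open whether this result is specific to chloro or would also hold for a fluoro, methyl or methoxy group on the phenyl ring. Also open, going by these compounds, is how a pyridine ring in place of the phenyl would compare with compound 1.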